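Propyl-to-methyl trim on an inactive core

A few compounds are considered here, and "the series" means these few. Any claim that something is new, unique, unknown or untested is made for them only; others in the source may bear on it.

Compound 1 `CCCc1cnc(Nc2cc[nH]n2)n2c(CCC)nc(C)c12` was tested in a functional assay for inhibition, with Homo sapiens as the target; a higher number here means a weaker inhibitor, a lower number a stronger inhibitor. In this assay compound 1 gives > 48000 nM, which is a limit of the assay and not a number. Compound 2 `CCc1nc(C)c2cnnc(SC)n12`, a different scaffold carrying a methylthio group, was measured in this assay as well. In this assay compound 2 gives > 48000 nM, again a limit and not a number. For the measured compounds named here, the only evidence on hand is therefore (the limit of > 48000 nM in this assay, at which 2 of the 2 values shown sit); neither compound shows a measurable value, and no step between measured compounds can be drawn.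

Compound 3 `CCCc1nc(C)c2c(C)cnc(Nc3cc[nH]n3)n12` is to be measured next. It differs from compound 1 by hydrogen in place of ethyl on a saturated chain carbon bound to an aromatic carbon, or, cut one bond further out, propyl to methyl. With compound 1 sitting at the limit, no step beyond the scatter is expected from compound 1 to compound 3 in this assay, and the expected step is a step that the limit leaves unreadable from compound 1 to compound 3. Compound 3 is expected to sit at about 60000 nM, with a range from 20000 nM to 200000 nM, most likely reported again only as a limit.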

Compound 3, half-maximal inhibitory concentration: > 48000 nM
Compound 3: only a limit was reported; the forecaster's own chance of this, stated with the estimate: 80%; the middle value is on the limit's open side.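

On these data alone, compound 3 gives a limit and not a number, as compound 1 does, so no step can be read between compound 1 and compound 3, and the size of the propyl to methyl change stays unknown. The compounds shown leave open whether any change on the shared core gives a readable value in this assay: the limit of > 48000 nM in this assay, at which 3 of the 3 values shown sit.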